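The compounds below may be only part of what the source reports. "The series", "measured", "known", "first", "only" and "open" are said of these compounds alone.

Series notes. Compound 2 `COc1ccc(Oc2ccc3c(NCCCNCc4cc(F)ccc4OC)ccnc3c2)cc1` and compound 3 `COc1ccc(Oc2ccc3c(NCCCNCc4ccco4)ccnc3c2)cc1` share one core and differ by furan-2-yl in place of 5-fluoro-2-methoxyphenyl on a saturated chain carbon bound to an amine nitrogen. In a physicochemical assay for solubility, with a stated time of 18 h, at pH 7.4 (a lower number here means a less soluble compound, a higher number a more soluble compound), compound 2 gives 14500 nM, and compound 3 gives 14500 nM, which is no change at the digits printed from compound 2 to compound 3 (within the scatter). Compound 1 `COc1ccc(F)cc1CNCCCNc1ccnc2cc(Cc3ccc(C#N)cc3)ccc12` carries 4-cyanobenzyl in place of 4-methoxyphenoxy on an aromatic carbon relative to compound 2, and in this assay compound 1 gives 4200 nM; the step is a 3.5-fold lower number from compound 2 to compound 1 (0.54 log units; beyond the scatter). Compound 4 `N#Cc1ccc(Cc2ccc3c(NCCCNCc4ccco4)ccnc3c2)cc1` is not yet measured. Against compound 3 it carries 4-cyanobenzyl in place of 4-methoxyphenoxy on an aromatic carbon, the same change as from compound 2 to compound 1, the place being described in the same words both times; the change occurs twice among these four compounds, once measured. For compound 4 the expected step in this assay is a 3.5-fold lower number from compound 3 to compound 4 (0.54 log units; beyond the scatter), set beside the measured 3.5-fold lower number from compound 2 to compound 1 (0.54 log units; beyond the scatter). The expectation rests on that single measured step and on compound 3 giving 14500 nM, level with compound 2 as the starting point. Compound 4 is therefore estimated at 4200 nM. Among the compounds with values here, the expected range for compound 4 runs from 2000 nM to 9000 nM, held loosely since only one instance of the change has been measured.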

Compound 4, solubility: 4200 nM
For compound 4 middle estimate and measured number coincide at the digits printed, within the range that was stated.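

In this assay, 4-cyanobenzyl in place of 4-methoxyphenoxy gives a 3.5-fold lower number from compound 3 to compound 4 (0.54 log units; beyond the scatter) on the furan-2-yl core, the same size as a 3.5-fold lower number from compound 2 to compound 1 (0.54 log units; beyond the scatter) on the 5-fluoro-2-methoxyphenyl core, so the change carried across these two cores without loss. The other edge of the square agrees, since furan-2-yl in place of 5-fluoro-2-methoxyphenyl gives no change at the digits printed from compound 2 to compound 3 (within the scatter) and also no change at the digits printed from compound 1 to compound 4 (within the scatter), and the two changes therefore combine here without visible interplay. This rests on two instances of the change on cores that differ in one group only, so it does not show that the step holds on more distant cores, and nothing measured bears on why the read-out moves as it does.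

Going by these compounds, whether a carboxylic acid or a piperidine in place of 4-cyanobenzyl would follow the same step remains open. A longer chain linking the two amine nitrogens is also untested by the compounds shown, so the reach of this additivity beyond the present chain stays unknown.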